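The compounds below may be only part of what the source reports. "The series", "measured", "known", "first", "only" and "open" are said of these compounds alone.

Working notes on the series: three compounds sharing one core have values so far in a physicochemical assay for lipophilicity, at pH 7.4; on this read-out higher numbers stand for higher lipophilicity and lower numbers for lower lipophilicity. Compound 2 (`CC(C)CN(c1ccc(C#N)cc1)S(=O)(=O)c1ccc2c(c1)C(=O)CC(C1CCOCC1)O2`) gives 3.16, the lowest of the three. Compound 1 (`O=C1CC(C2CCOCC2)Oc2ccc(S(=O)(=O)N3CCCC3c3ccccc3C(F)(F)F)cc21`) is the nearest at 3.5, and compound 3 (`CCc1ccc(N(Cc2ccccc2)S(=O)(=O)c2ccc3c(c2)C(=O)CC(C2CCOCC2)O3)cc1`) the furthest at 4.84, both gaps lying beyond the scatter.

The next compound to be read is compound 4 (`CC(C)CN(c1ccc(F)cc1F)S(=O)(=O)c1ccc2c(c1)C(=O)CC(C1CCOCC1)O2`). Its change from compound 2 is 2,4-difluorophenyl in place of 4-cyanophenyl on a sulfonamide nitrogen. The core and the other groups stay the same.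

For the measured compounds named here, no measured pair differs in one place only, so the data offer no direct precedent for this swap, and the expectation rests on the structural change alone. A moderate upward move in this assay, beyond the scatter, is expected. The expected size is a number 0.54 log units higher from compound 2 to compound 4 (beyond the scatter). For compound 4 the estimated value is 3.7, with an expected range of 3.3 to 4.1.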

Compound 4, distribution coefficient: 3.62
Beside the measured number, compound 4's estimate is 0.08 log units above it; measured number inside the range.
By their numbers in this assay, from the lowest: compound 2; then compounds 1 and 4 (each within the scatter of the next); then compound 3.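

On the sulfonamide nitrogen whose other neighbours are a saturated chain carbon and the sulfonyl sulfur, the series now has its first step in one place: in this assay, 2,4-difluorophenyl in place of 4-cyanophenyl gives a number 0.46 log units higher from compound 2 to compound 4 (beyond the scatter) with the core and the other groups unchanged. The aryl group at this place can therefore move the read-out on its own, here in a swap that keeps the heavy-atom count and removes the nitrile with its counted hydrogen-bond acceptor. Nothing at hand gives a measured reason for this step.

The compounds shown leave open how much of the step follows the loss of the nitrile and how much each fluorine adds. From the compounds shown here alone, how an aryl group carrying an amine or a carboxylic acid would read at this place also stays open.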